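This account rests on a few compounds, and the source may have more. Where it says the series, first, only, none or still open, it means among the compounds named here.

Compound 1 `NS(=O)(=O)CC(=O)NCCSc1nonc1/C(=N/O)Nc1cccc(C(F)F)c1` carries a sulfamoylacetamide chain on the shared core. In an ADME assay on isolated protein for pharmacokinetics, with UDP-glucuronosyltransferase 1A9 (Homo sapiens) as the target, read by LC-MS, with a stated time of 60 min, at 37 degrees C, tested at 1 uM, in the presence of a further agent that is not named here (a lower number here means that the compound disappears faster, a higher number that the compound lasts longer), compound 1 reaches only a limit of the assay, > 3 h. Compound 2 `CS(=O)(=O)NCCSc1nonc1/C(=N/O)Nc1ccc(F)c(Br)c1` bears a methanesulfonamide chain instead, and in this assay compound 2 gives 0.357 h. Compound 3 `N#Cc1cc(N/C(=N\O)c2nonc2SCCNC(=O)CS(N)(=O)=O)ccc1F` has not been measured yet; it differs from compound 1 by 3-cyano-4-fluorophenyl in place of 3-(difluoromethyl)phenyl on an amine nitrogen. With no measured step of this kind shown, the expected change an at least 1.2-fold lower number from compound 1 to compound 3 (0.07 log units; that floor lies within the scatter) is small, within the usual scatter or a modest shortening. Compound 3 is therefore estimated at 2.5 h, with a likely range from 1 h to 6 h.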

Compound 3, half-life: > 3 h
Compound 3 was reported as a limit (the forecaster's own chance of this, stated with the estimate: 40%); middle value at least 1.2-fold (0.07 log units) away from the limit.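

No step can be read from compound 1 to compound 3, because both values are limits of the assay: the limit of > 3 h in this assay, at which 2 of the 3 values shown sit.

As far as these compounds go, whether 3-cyano-4-fluorophenyl or 3-(difluoromethyl)phenyl gives the longer half-life in this assay stays open.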